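Lengthening a Saturated Chain on the Shared Core

The source may report more compounds than this note shows. Statements on the series, on what has been measured and on what is new or still open speak of the compounds shown alone.

Compound 3 `CCCCc1ccc(NC(=O)N[C@H](C)c2ccccc2)cc1` gives 28% in an ADME assay on the whole organism with Oryza sativa as the target, tested at 10 uM (a higher number here means a weaker effect of the compound at the concentration tested, a lower number a stronger effect), the lowest of the three numbers recorded so far. Its nearest neighbour is compound 2 `CCCc1ccc(NC(=O)N[C@H](C)c2ccccc2)cc1`, which gives 35% in this assay; a number 7 percentage points lower from compound 2 to compound 3 (within the scatter). Compound 1 `Cc1ccc(NC(=O)N[C@H](C)c2ccccc2)cc1` lies furthest away and gives 64% in this assay; a number 36 percentage points lower from compound 1 to compound 3 (beyond the scatter). Compound 4 `CCCCCCCc1ccc(NC(=O)N[C@H](C)c2ccccc2)cc1` has not yet been measured. It differs from compound 3 in one place: propyl in place of hydrogen on a saturated chain carbon, four bonds along the chain from an aromatic carbon. Among the measured compounds shown here, three measured steps bear on this change, each adding carbon to the same chain. a number 29 percentage points lower from compound 1 to compound 2 (beyond the scatter); a number 36 percentage points lower from compound 1 to compound 3 (beyond the scatter); yet a number 7 percentage points lower from compound 2 to compound 3 (within the scatter). The later extension of the chain added little to the earlier one, so a further lengthening is expected to lower the number only modestly, if beyond the scatter at all. Compound 4 is therefore estimated at 18% in this assay, with a range from 5% to 35%, which means an expected change of a number 10 percentage points lower from compound 3 to compound 4 (within the scatter).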

Compound 4, a percentage reported as activity, at one concentration (the size of the read-out at that concentration, not a potency): 100%
For compound 4 the middle estimate is 82 percentage points below the measured one, outside the stated range (above it).
By their numbers in this assay, from the lowest: compounds 3 and 2 (each within the scatter of the next); then compound 1; then compound 4.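

At this position the direction of the change reverses in this assay: adding propyl to the chain gives a number 72 percentage points higher from compound 3 to compound 4 (beyond the scatter), so lengthening the chain does not keep lowering the number. The longest chain also stands apart from the two next shorter ones, with a number 65 percentage points higher from compound 2 to compound 4 (beyond the scatter) and a number 36 percentage points higher from compound 1 to compound 4 (beyond the scatter), which means that across these four compounds the number falls and then rises with chain length, ending at a weaker effect than any shorter chain gives. No measurement at hand offers a reason for this turn.

The compounds shown leave open how the number runs through chains of intermediate length, such as pentyl or hexyl in this place. They also leave open whether an amine or a carboxylic acid on the chain would keep the lower numbers.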